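Substituent swaps on the distal ring: chloro to trifluoromethoxy

The source may report more compounds than this note shows. Statements on the series, on what has been measured and on what is new or still open speak of the compounds shown alone.

Three analogues share one core. Compound 1 `Oc1ccccc1CNc1ccc(-c2ccc(F)cc2)cc1` gives 3860 nM in a functional assay on Jurkat cells (Homo sapiens) for activation, with a stated time of 24 h; a lower number here means that less compound is needed, a higher number that more compound is needed for the effect. Compound 2 `Cc1ccc(-c2ccc(NCc3ccccc3O)cc2)cc1` gives 3790 nM in this assay, and compound 3 `Oc1ccccc1CNc1ccc(-c2cccc(Cl)c2)cc1` gives 6200 nM in this assay. The three differ only on the distal ring; the steps of a 1.0-fold lower number from compound 1 to compound 2 (0.01 log units; within the scatter), a 1.6-fold higher number from compound 1 to compound 3 (0.21 log units; within the scatter) and a 1.6-fold higher number from compound 2 to compound 3 (0.21 log units; within the scatter) all stay within the scatter, so compound 3 sits with compound 1 and compound 2 and no order among them can be claimed.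

Compound 4 `Oc1ccccc1CNc1ccc(-c2cccc(OC(F)(F)F)c2)cc1` continues from compound 3 by trifluoromethoxy in place of chloro on an aromatic carbon. Among the compounds with values here, no measured pair exchanges chloro for trifluoromethoxy; the steps that bear on it are the substituent changes on the same ring, all within the scatter. On that basis compound 4 is expected to give about 6000 nM in this assay, with a range from 2500 nM to 14000 nM. The expected step is a 1.0-fold lower number from compound 3 to compound 4 (0.01 log units; within the scatter), within the scatter, because a 1.6-fold higher number from compound 1 to compound 3 (0.21 log units; within the scatter) and a 1.6-fold higher number from compound 2 to compound 3 (0.21 log units; within the scatter) show that ring substituent changes here moved little.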

Compound 4, half-maximal effective concentration: "not active" (no number reported)
The entry for compound 4 holds no number; there is nothing to compare the estimate with.
By their numbers in this assay, from the lowest: compounds 2, 1 and 3 (each within the scatter of the next).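

Within the data shown here, compound 4 is entered as not active, without a number, in this assay; no step from compound 1, compound 2 or compound 3 to compound 4 can be read. Nothing available accounts for that entry. The compounds shown leave open how far trifluoromethoxy in place of chloro shifts the response.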